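The compounds below may be only part of what the source reports. "The series", "measured", "known", "first", "only" and "open" are said of these compounds alone.

Measured compounds:
compound 1, `CCCC(=O)NCC1CCc2ccc(OC)cc21`, which in an assay for binding affinity to melatonin receptor type 1B (Gallus gallus), read by radioligand binding (on this read-out higher numbers stand for weaker inhibition and lower numbers for stronger inhibition), gives 7.6 nM;
compound 2, `CCC(=O)NCC1CCCc2ccc(OC)cc21`, which in this assay gives 0.53 nM; > 1000 nM; 0.45 nM (3 entries), several entries taken together (the several entries of compound 2 in this assay, 0.53 nM; > 1000 nM; 0.45 nM (3 entries)).

For compound 1 the value given is the only number shown; a further entry exists without a single number, so compound 1 stands on one measurement alone. Compound 3, `COc1ccc2c(c1)C(CNC(C)=O)CC2`, has not yet been measured in this assay. It differs from compound 1 by hydrogen in place of ethyl on a saturated chain carbon bound to a carbonyl carbon, that is, propylcarbonyl to acetyl on the core of compound 1. For the measured compounds named here, no step between two measured compounds covers this change, so the size of the step rests on expectation alone. The account expects a modest weakening, if any, for the step of a 1.6-fold higher number from compound 1 to compound 3 (0.20 log units; within the scatter), not clearly beyond the scatter. Compound 3 is therefore estimated at 12 nM, within a range from 3 nM to 50 nM.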

Compound 3, inhibition constant: 77 nM
Compound 3: the middle estimate sits 6.4-fold (0.81 log units) below what was measured, and the stated range ends below it.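

In this assay the acyl chain on the core of compound 1 proves not to be a free place: hydrogen in place of ethyl on a saturated chain carbon bound to a carbonyl carbon gives a 10-fold higher number from compound 1 to compound 3 (1.01 log units; beyond the scatter) and so counts as a large change. For the compounds shown here, this is the first step that can be read at this position, and it shows that shortening propylcarbonyl to acetyl costs binding on this core, which the earlier compounds could not show. Nothing among the compounds shown gives a cause for a step of this size.

On these data alone, it remains open whether a longer chain, such as butylcarbonyl, or a cyclopropylcarbonyl group would lower the number further on this core. As far as these compounds go, it also remains open where ethylcarbonyl would fall on this core, so a single step cannot say whether the loss grows evenly with shortening.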